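Swapping a fluorinated sugar for a hydroxylated one

The compounds below may be only part of what the source reports. "The series", "measured", "known", "first", "only" and "open" are said of these compounds alone.

Compound 1, `N=C(N)NCCC[C@H](N)C(=O)NCC(=O)N[C@@H](CC(=O)O)C(=O)N[C@@H](CSCc1cn(CCO[C@H]2O[C@H](CF)[C@@H](O)[C@H](O)[C@H]2O)nn1)C(=O)O`, in a functional assay on a cell-free system (Platelet, plasma, Homo sapiens) for inhibition, with a stated time of 10 min, at 37 degrees C (a higher number here means a weaker inhibitor, a lower number a stronger inhibitor), gives 26000 nM.
Compound 2, `N=C(N)NCCC[C@H](N)C(=O)NCC(=O)N[C@@H](CC(=O)O)C(=O)N[C@@H](CSCc1cn(CCO[C@@H]2O[C@H](CF)[C@@H](O)[C@H](O)[C@H]2O)nn1)C(=O)O`, in this assay gives 66000 nM.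

Compound 2 stands highest of the two numbers. Among the compounds with values here, the only measured step is a 2.5-fold higher number from compound 1 to compound 2 (0.40 log units; beyond the scatter); it rests on the fact that one of compounds 1 and 2 is drawn with a defined configuration and the other without, at the place where they differ and tells nothing about the sugar itself. Compound 3, `N=C(N)NCCC[C@H](N)C(=O)NCC(=O)N[C@@H](CC(=O)O)C(=O)N[C@@H](CSCc1cn(CCO[C@H]2O[C@H](CO)[C@@H](O)[C@H](O)[C@@H]2O)nn1)C(=O)O`, differs from compound 2 by a group of 11 heavy atoms (6 carbon, 5 oxygen; one six-membered non-aromatic ring with 1 hetero atom) in place of a group of 11 heavy atoms (6 carbon, 4 oxygen, 1 fluorine; one six-membered non-aromatic ring with 1 hetero atom), on an oxygen on a saturated carbon. Within the data shown here, no measured step exchanges fluorine for oxygen, so the expected step is small: a 1.7-fold lower number from compound 2 to compound 3 (0.22 log units; within the scatter). Compound 3 is estimated at 40000 nM, within 15000 nM to 110000 nM.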

Compound 3, half-maximal inhibitory concentration: 47600 nM
Beside the measured number, compound 3's estimate is 1.2-fold (0.08 log units) below it; low and high end bracket the measured number.
By their numbers in this assay, from the lowest: compounds 1, 3 and 2 (each within the scatter of the next, the first and the last beyond it).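

Within the data shown here, exchanging the fluorinated sugar for the hydroxylated one gives no step that can be told from scatter: a 1.4-fold lower number from compound 2 to compound 3 (0.14 log units; within the scatter), and a 1.8-fold higher number from compound 1 to compound 3 (0.26 log units; within the scatter). In this assay, compound 3 therefore cannot be separated from compound 1 or compound 2, although those two can be separated from each other. Nothing measured here gives a reason for this result.

The compounds shown leave open whether the sugar itself matters at this place. Going by these compounds, it is also open what an amine or a carboxylic acid would do there in its stead.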